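A few compounds are considered here, and "the series" means these few. Any claim that something is new, unique, unknown or untested is made for them only; others in the source may bear on it.

Compound 3, with the structure `NC(=O)c1c(NC(=O)c2ccccc2C(F)(F)F)sc2c1CCN(C(=S)Nc1ccccc1Br)C2`, gives 25500 nM in a functional assay on HL-60 cells (Homo sapiens) for antiproliferative activity, with a stated time of 24 h; a higher number here means a weaker inhibitor, a lower number a stronger inhibitor. Among the two values that are numbers rather than limits, compound 3 carries the lowest one, but its nearest neighbour, compound 1 with the structure `COc1ccccc1NC(=S)N1CCc2c(sc(NC(=O)c3ccccc3Cl)c2C(N)=O)C1`, gives 40900 nM in this assay, a gap that stays within the usual scatter, so the two cannot be ranked. Compound 2, with the structure `COc1ccccc1NC(=S)N1CCc2c(sc(NC(=O)c3ccccc3I)c2C(N)=O)C1`, reaches only a limit in this assay, > 50000 nM, and this is the limit of > 50000 nM in this assay, at which 1 of the 3 values shown sits.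

Going by the values given here, the only step measured here in one place is an at least 1.2-fold higher number from compound 1 to compound 2 (0.08 log units; that floor lies within the scatter). It concerns a halogen swap on a different part of the core and so offers no direct guide to the change in hand.

Compound 4, with the structure `COc1ccccc1NC(=S)N1CCc2c(sc(NC(=O)c3ccccc3C(F)(F)F)c2C(N)=O)C1`, differs from compound 3 by methoxy in place of bromo on an aromatic carbon. Compound 1 and compound 2 already carry methoxy at that place, and their values sit near or above the value of compound 3. Nothing measured therefore points to a shift beyond the scatter, and the step from compound 3 to compound 4 is estimated as a 1.2-fold higher number from compound 3 to compound 4 (0.07 log units; within the scatter). Compound 4 is accordingly expected to give about 30000 nM in this assay, within a range from 12000 nM to 80000 nM.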

Compound 4, half-maximal inhibitory concentration: > 50000 nM
Compound 4: a limit, no number (the forecaster's own chance of this, stated with the estimate: 25%); at least 1.6-fold (0.22 log units) between middle value and limit.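

Replacing bromo with methoxy on this aromatic carbon, with the rest of the molecule unchanged, gives an at least 1.9-fold higher number from compound 3 to compound 4 (0.29 log units; that floor lies within the scatter) in this assay; this is the only direct test of the change, and it sets only a floor. Compound 4 gives a limit rather than a number, so methoxy at this place has no measured value to set against bromo, and the data show neither a real loss nor the absence of one. Trifluoromethyl in place of chloro, with methoxy already present, gives an at least 1.2-fold higher number from compound 1 to compound 4 (0.08 log units; that floor lies within the scatter), the step between compound 2 and compound 4 cannot be read, and the size of these changes stays hidden because several values sit at one limit: the limit of > 50000 nM in this assay, at which 2 of the 4 values shown sit.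

Going by these compounds, it remains open whether this place accepts other groups, such as an amine, a hydroxyl or a carboxylic acid on the same aromatic carbon, or whether a plain hydrogen there would give a similar value. Among the compounds shown, compound 3 alone carries bromo, so it is also open whether the same swap would behave alike with chloro or iodo in place of trifluoromethyl.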